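The source may report more compounds than this note shows. Statements on the series, on what has been measured and on what is new or still open speak of the compounds shown alone.

Compound 2, `Cc1c(Br)cc(C(=O)NC2CCCCCC2)c(=O)n1Cc1ccc(F)cc1`, sits at the weaker end of the numbers available in an assay on U-937 cells for inhibition of Fatty-acid amide hydrolase 1 (Homo sapiens), read by scintillation counting, with a stated time of 15 min; a lower number here means a stronger inhibitor, a higher number a weaker inhibitor: in this assay compound 2 gives 5900 nM. Its nearest neighbour is compound 1, `Cc1c(-c2ccc(F)cc2)cc(C(=O)NC2CCCCCC2)c(=O)n1Cc1ccc(F)cc1`, which in this assay gives 530 nM; the step of an 11-fold higher number from compound 1 to compound 2 (1.05 log units; beyond the scatter) is large. Compound 3, `Cc1c(Br)cc(C(=O)NC2CCNCC2)c(=O)n1Cc1ccc(F)cc1`, is reported only as a limit of this assay, > 10000 nM (the limit of > 10000 nM in this assay, at which 1 of the 3 values shown sits). The step of an at least 1.6-fold higher number from compound 2 to compound 3 (0.22 log units; that floor lies within the scatter) is therefore only a floor.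

Compound 4, `Cc1c(F)cc(C(=O)NC2CCCCCC2)c(=O)n1Cc1ccc(F)cc1`, differs from compound 2 by fluoro in place of bromo on an aromatic carbon, at the position ortho to a methyl group and meta to the 4-fluorobenzyl group. Among the measured compounds shown here, neither measured step directly tests one halogen against another at this position; the only step at this carbon, an 11-fold higher number from compound 1 to compound 2 (1.05 log units; beyond the scatter), shows that shrinking the group from 4-fluorophenyl to bromo costs a great deal. Shrinking further to fluoro is expected to cost somewhat more, or at best to stay within the scatter, so the step of a 1.5-fold higher number from compound 2 to compound 4 (0.18 log units; within the scatter) is estimated as a modest rise. Compound 4 is thus expected to give about 9000 nM in this assay, in a range from 3000 nM to 27000 nM, with a fair chance that only a limit is reported.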

Compound 4, half-maximal inhibitory concentration: > 10000 nM
Compound 4 gave a limit, no number; the forecaster's own chance of this, stated with the estimate: 45%; at least 1.1-fold (0.04 log units) between middle value and limit.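

In this assay compound 4 is reported only as a limit: the limit of > 10000 nM in this assay, at which 2 of the 4 values shown sit. The step of an at least 1.6-fold higher number from compound 2 to compound 4 (0.22 log units; that floor lies within the scatter) is therefore only a floor, so the exchange of bromo for fluoro on this aromatic carbon cannot be sized, and it is not shown to matter beyond the scatter. The new information is the span at this carbon: the step of an at least 18-fold higher number from compound 1 to compound 4 (1.27 log units; beyond the scatter) is large even as a floor, so 4-fluorophenyl stands well apart from fluoro as well as from bromo.

On these data alone, how a chloro group, a methoxy group or a phenyl ring without its fluoro would read at this carbon remains open. Also open, as far as these compounds go, is whether 4-fluorophenyl would keep its advantage with piperidin-4-yl in place of cycloheptyl on the amide-type nitrogen.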